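Naphthalen-1-yl for 2-chlorophenyl on the amine of compound 2

This account rests on a few compounds, and the source may have more. Where it says the series, first, only, none or still open, it means among the compounds named here.

Values in an assay on COS-7 cells for inhibition of sodium/nucleoside cotransporter 2 (Homo sapiens), read by scintillation counting, in the presence of a further agent that is not named here; on this read-out higher numbers stand for weaker inhibition and lower numbers for stronger inhibition:
Compound 1 `CC(=O)OC[C@H]1O[C@@H](n2cnc3c(N)ncnc32)[C@H](O)[C@@H]1O` gives > 100000 nM, a limit of the assay.
Compound 2 `Nc1ncnc2c1nc(NCc1ccccc1Cl)n2[C@@H]1O[C@H](CO)[C@@H](O)[C@H]1O` gives 5700 nM.
Compound 3 `Nc1ncnc2c1ncn2[C@@H]1O[C@H](COC(=O)NCc2ccccc2)[C@@H](O)[C@H]1O` gives > 100000 nM, a limit of the assay.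
Compound 4 `Nc1ncnc2c1nc(NCc1cccc3ccccc13)n2[C@@H]1O[C@H](CO)[C@@H](O)[C@H]1O` is not yet measured.

Among the measured compounds shown here, compound 2 stands alone: in this assay it gives the only real number among the three values, since the other two sit at the limit of > 100000 nM in this assay, at which 2 of the 3 values shown sit. For the measured compounds named here, the single step between measured compounds, a step that the two limits leave unreadable from compound 1 to compound 3, runs between two limits and its size cannot be read. Compound 4 differs from compound 2 as follows: naphthalen-1-yl in place of 2-chlorophenyl on a saturated chain carbon bound to a nitrogen on an aromatic ring. Going by the values given here, no measured step touches this kind of change, so nothing in the data shows whether a larger aromatic group on that carbon helps or hurts. With the position of the substituent kept and only its size changed, the expectation is a step no larger than the scatter, written as a 1.3-fold lower number from compound 2 to compound 4 (0.10 log units; within the scatter). Compound 4 is therefore estimated at 4500 nM, within a range from 1000 nM to 25000 nM.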

Compound 4, half-maximal inhibitory concentration: 5700 nM
The estimate for compound 4 lay 1.3-fold (0.10 log units) below the measured number, and the stated range covers the measured number.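

In this assay, putting naphthalen-1-yl in place of 2-chlorophenyl gives no change at the digits printed from compound 2 to compound 4 (within the scatter). Among the compounds shown here, this is the first step in the set that can be read, and it shows that on a saturated chain carbon bound to a nitrogen on an aromatic ring, a group of 10 carbon atoms in two aromatic rings can replace one with a single ring and a chlorine, with the two values remaining within the scatter of each other. The only earlier step cannot be read, as both of its ends are limits and not numbers: the limit of > 100000 nM in this assay, at which 2 of the 4 values shown sit.

The compounds shown leave open whether plain phenyl, or an amine or a carboxylic acid on the ring, would give a value like these two. They also leave open what a longer chain in place of that saturated carbon would do.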